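Swapping sec-Butyl for 1,2-Oxazol-3-yl on the Amide Nitrogen

The source may report more compounds than this note shows. Statements on the series, on what has been measured and on what is new or still open speak of the compounds shown alone.

Measured so far:
compound 1, `CCN(Cc1cccs1)C(=O)c1cc2cc(C)ccc2s1`: 1600 nM
compound 2, `CCC(C)N(Cc1cccs1)C(=O)COc1ccc(C)cc1`: 2000 nM
compound 3, `CCN(Cc1nccs1)C(=O)COc1ccc(C)cc1`: 3060 nM

These three numbers come from an assay on HEK293 cells for agonist activity at transient receptor potential cation channel subfamily M member 8 (Homo sapiens), read by fluorescence and calcium flux, with a stated time of 15 min; on this read-out lower numbers stand for an effect already at smaller amounts and higher numbers for an effect only at larger amounts of compound. Compound 2 sits in the middle of the three; its gap to compound 1 and its gap to compound 3 both lie within the usual scatter, so none of the three can be set above or below another. Compound 4, `Cc1ccc(OCC(=O)N(Cc2cccs2)c2ccon2)cc1`, has not yet been measured. Compared with compound 2 it carries 1,2-oxazol-3-yl in place of sec-butyl on an amide-type nitrogen. Among the compounds with values here, no measured pair shows this change, so there is no step to lean on. The step of a 1.3-fold higher number from compound 2 to compound 4 (0.10 log units; within the scatter) is expected to stay within the scatter. Compound 4 in this assay is expected at 2500 nM, with a range from 800 nM to 8000 nM.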

Compound 4, half-maximal effective concentration: 2 nM
Estimate against measurement, compound 4: 1300-fold (3.10 log units) above; measured number below the stated range.
By their numbers in this assay, from the lowest: compound 4; then compounds 1, 2 and 3 (each within the scatter of the next).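

Within the data shown here, putting 1,2-oxazol-3-yl in place of sec-butyl on this amide-type nitrogen gives a 1000-fold lower number from compound 2 to compound 4 (3.00 log units; beyond the scatter) and is the first sign that this position can shift the number strongly. The step swaps a ring-free chain for a five-membered aromatic ring with 2 hydrogen-bond acceptors, but it cannot show which of these differences matters. Nothing available explains the size of this step. As far as these compounds go, it remains open whether another ring on this nitrogen, such as phenyl or pyridine, would give a similar number, or whether only 1,2-oxazol-3-yl does.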